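The source may hold more compounds than are shown below. What is called first, only, known or untested is meant among the compounds shown, and "the series" means these compounds.

Compound 1 `O=C(NCCCCn1cccn1)c1cccc(C2SCC(=O)N2c2cccnc2)c1` is the starting point of this step. In a functional assay on HOS-TE85 cells (Homo sapiens) for inhibition, read by CCK-8 assay, with a stated time of 72 h (a higher number here means a weaker inhibitor, a lower number a stronger inhibitor), compound 1 gives > 1000 nM, which is a limit of the assay and not a measured number. Compound 2 `COc1cccc(OC)c1N1C(=O)CSC1c1cccc(C(=O)NCCCCc2ccccc2)c1` likewise gives only > 1000 nM in this assay, again a limit. Compound 3 `O=C(NCCCCc1ccccc1)c1cccc(C2SCC(=O)N2c2cccc(F)c2)c1` gives 32.4 nM in this assay. Among the measured compounds shown here, the one measured step touching the same position is an at least 30-fold lower number from compound 2 to compound 3 (1.48 log units; beyond the scatter), a large change, though compound 2 and compound 3 carry a different chain on the amide than compound 1. Compound 4 `O=C(NCCCCn1cccn1)c1cccc(C2SCC(=O)N2c2cc(Br)ccn2)c1` differs from compound 1 by 4-bromopyridin-2-yl in place of pyridin-3-yl on an amide-type nitrogen in a ring. For the measured compounds named here, the group on the amide-type nitrogen in the ring thus matters in the measured data, but no step with the chain of compound 1 has been measured, and the position of compound 1 at the limit of > 1000 nM in this assay, at which 2 of the 3 values shown sit, leaves the size of any gain open. Compound 4 is therefore expected to land near 600 nM, in a range from 60 nM to 3000 nM, with an uncertain step of an at least 1.6-fold lower number from compound 1 to compound 4 (0.22 log units; that floor lies within the scatter) expected.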

Compound 4, half-maximal inhibitory concentration: 105 nM
Estimate against measurement, compound 4: 5.7-fold (0.76 log units) above; the range from low to high includes it.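

Replacing pyridin-3-yl with 4-bromopyridin-2-yl on the amide-type nitrogen in the ring gives, in this assay, an at least 9.5-fold lower number from compound 1 to compound 4 (0.97 log units; beyond the scatter). Among the compounds shown here, the earlier step at this position was read only with the amide chain of compound 3, so this result is the first to show that the group here also matters with the chain of compound 1, and that a pyridine ring at this position can leave the limit. From the compounds shown here alone, the true size of the step stays unknown because the value for compound 1 is a limit and gives only a floor: the limit of > 1000 nM in this assay, at which 2 of the 4 values shown sit.

Both the bromine and the place of the ring nitrogen change in this one step, and the compounds shown do not tell which of them carries the gain. They also leave open how a chlorine, a methyl or a nitrile in place of the bromine would read.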